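Switching the biaryl substituent toward a fluoro-methyl pattern

The source may hold more compounds than are shown below. What is called first, only, known or untested is meant among the compounds shown, and "the series" means these compounds.

Compound 1 `Cc1cc(Cl)ccc1-c1cccc(COc2ccc([C@H](CC(=O)O)c3nccn3C)cc2)c1C`: 23000 nM
Compound 2 `COc1ccccc1-c1cccc(COc2ccc([C@H](CC(=O)O)c3nccn3C)cc2)c1`: "not determined" (no result reported)
Compound 3 `Cc1cc(Cl)ccc1-c1cc(COc2ccc([C@H](CC(=O)O)c3nccn3C)cc2)ccc1C`: 9800 nM

Three compounds sharing the same core have been examined in an assay on CHO cells for agonist activity at Free fatty acid receptor 1 (Homo sapiens), read by luminescence, with a stated time of 20 s, in the presence of a further agent that is not named here; on this read-out higher numbers stand for an effect only at larger amounts of compound and lower numbers for an effect already at smaller amounts. Compound 1 `Cc1cc(Cl)ccc1-c1cccc(COc2ccc([C@H](CC(=O)O)c3nccn3C)cc2)c1C` gives 23000 nM in this assay, and compound 3 `Cc1cc(Cl)ccc1-c1cc(COc2ccc([C@H](CC(=O)O)c3nccn3C)cc2)ccc1C` gives 9800 nM. Compound 2 `COc1ccccc1-c1cccc(COc2ccc([C@H](CC(=O)O)c3nccn3C)cc2)c1` carries a 2-methoxyphenyl group on the central ring, but for compound 2 this assay returned "not determined" (no result reported) and no number at all, so its standing among the shown values is unknown.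

Compound 4 `Cc1cc(F)ccc1-c1cccc(COc2ccc([C@H](CC(=O)O)c3nccn3C)cc2)c1` is the compound still to be measured. It differs from compound 2 in one place: 4-fluoro-2-methylphenyl in place of 2-methoxyphenyl on an aromatic carbon. The structural change brings in a 4-fluoro-2-methylphenyl group, with the fluorine and the methyl sitting on the outer ring, while the methoxy group of compound 2 is gone.

For the measured compounds named here, since no value exists for compound 2 and no step between measured compounds is available, the size of this step cannot be read from the data. The expectation rests only on compound 1 and compound 3, whose values place such biaryl compounds at fairly large concentrations in this assay. Compound 4 is therefore expected to fall in the same region, estimated at 8000 nM, within a range of 2500 nM to 25000 nM.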

Compound 4, half-maximal effective concentration: 21000 nM
Beside the measured number, compound 4's estimate is 2.6-fold (0.42 log units) below it; the measured number falls inside the stated range.
By their numbers in this assay, from the lowest: compound 3; then compounds 4 and 1 (each within the scatter of the next).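

In this assay, for the compounds shown here, compound 4 gives 21000 nM, but compound 2 has no reported number, so no step between compound 2 and compound 4 can be read. The compounds shown leave open how replacing 2-methoxyphenyl with 4-fluoro-2-methylphenyl shifts the value. Nothing shown offers an explanation for the value of compound 4.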